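Cyclising the amino alcohol on the alkyne arm

A few compounds are considered here, and "the series" means these few. Any claim that something is new, unique, unknown or untested is made for them only; others in the source may bear on it.

Measured so far:
compound 1, `COc1cc[nH]c1/C=C1\C(=O)Nc2ccc(F)c(C#C[C@@H](N)CO)c21`: 300 nM
compound 2, `CCN[C@H](C#Cc1c(F)ccc2c1/C(=C/c1[nH]ccc1OC)C(=O)N2)[C@@H](C)O`: 1070 nM
compound 3, `COc1cc[nH]c1/C=C1\C(=O)Nc2ccc(F)c(C#C[C@@H]3CCCN3)c21`: 31 nM

In a functional assay on MDA-MB-435 cells (Homo sapiens) for inhibition (a higher number here means a weaker inhibitor, a lower number a stronger inhibitor), compound 1 gives 300 nM, the second highest of the three numbers; compound 2 is close at 1070 nM, while compound 3 at 31 nM is clearly lower. Among the compounds with values here, compound 4, `COc1cc[nH]c1/C=C1\C(=O)Nc2ccc(F)c(C#C[C@@H]3C[C@@H](O)CN3)c21`, differs from compound 1 as follows. 4-hydroxypyrrolidin-2-yl in place of 1-amino-2-hydroxyethyl on a triple-bonded carbon The step that bears most on this change is a 9.7-fold lower number from compound 1 to compound 3 (0.99 log units; beyond the scatter), where closing the amino alcohol into a plain ring gave a clearly lower number; compound 4 keeps that ring but carries a hydroxyl on it, and no measured step tells how that hydroxyl matters. The step of a 3.6-fold higher number from compound 1 to compound 2 (0.55 log units; beyond the scatter) shows that growing the open chain instead raised the number. The expected move is therefore a 6.0-fold lower number from compound 1 to compound 4 (0.78 log units; beyond the scatter), a lower number. For compound 4 the estimate in this assay is 50 nM, between 15 nM and 160 nM.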

Compound 4, half-maximal inhibitory concentration: 63 nM
Compound 4: the middle estimate sits 1.3-fold (0.10 log units) below what was measured; low and high end bracket the measured number.
By their numbers in this assay, from the lowest: compound 3; then compound 4; then compound 1; then compound 2.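

In this assay, the closed ring keeps most of its advantage when it carries a hydroxy group, as the open chains show (a 4.8-fold lower number from compound 1 to compound 4 (0.68 log units; beyond the scatter); a 17-fold lower number from compound 2 to compound 4 (1.23 log units; beyond the scatter)). The hydroxy group itself gives a small step the wrong way (a 2.0-fold higher number from compound 3 to compound 4 (0.31 log units; beyond the scatter)), so on this ring it is tolerated but brings no gain. No evidence here explains this step. 

From the compounds shown here alone, whether an amine or a carboxylic acid on that saturated ring carbon would do better stays open. So does whether the opposite stereocentre at the hydroxy carbon would change the number.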